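The compounds below may be only part of what the source reports. "The series", "measured", "known", "first", "only" and "open" are said of these compounds alone.

Of the compounds shown here, three have been tested in an ADME assay on HepG2 cells (Homo sapiens) for cytotoxicity, read by CellTiter-Glo and resazurin assay, with a stated time of 72 h; a lower number here means that less compound is needed, a higher number that more compound is needed for the effect. Compound 1 `CC(C)N(Cc1cccc(OCCCCCC(=O)O)c1)C(=O)c1ccc(-c2cccc(C(F)(F)F)c2)cc1` reaches only a limit there, > 26000 nM. Compound 2 `CCOC(=O)CCCCCOc1cccc(CN(C(=O)c2ccc(-c3cccnc3)cc2)C(C)C)c1` likewise gives a limit, > 26000 nM. Compound 3 `CCOC(=O)CCCCCOc1cccc(CN(C(=O)c2ccc(-c3cccc(Oc4ccccc4)c3)cc2)C(C)C)c1` also returns a limit, > 26000 nM. All three values therefore sit at the limit of > 26000 nM in this assay, at which 3 of the 3 values shown sit, and compound 3 stands with the others there. The unmeasured compound 4 `CCOC(=O)CCCCCOc1cccc(CN(C(=O)c2ccc(-c3cccc(C(F)(F)F)c3)cc2)C(C)C)c1` differs from compound 3 by trifluoromethyl in place of phenoxy on an aromatic carbon. Compound 1 already carries a trifluoromethyl group and gives > 26000 nM in this assay, so no step beyond the usual scatter is expected on going from compound 3 to compound 4. Compound 4 is thus expected to give 40000 nM (range 26000 nM to 100000 nM), most likely again reported only as a limit. The implied step that the limit leaves unreadable from compound 3 to compound 4 is expected to be essentially none.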

Compound 4, half-maximal effective concentration: > 26000 nM
Compound 4 was reported as a limit; the forecaster's own chance of this, stated with the estimate: 90%; the middle value is on the limit's open side.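

Compound 4, like compound 1, compound 2 and compound 3, gives only a limit in this assay, so no step among them can be read: the limit of > 26000 nM in this assay, at which 4 of the 4 values shown sit.

The compounds shown leave open what concentration, if any, produces the half-maximal effect for any of them.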